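A few compounds are considered here, and "the series" means these few. Any claim that something is new, unique, unknown or untested is made for them only; others in the source may bear on it.

Compound 1 `Cc1c(C)n(Cc2ccccc2)c2ncn(C3CCOCC3)c(=N)c12` is the only entry with a single measured number: in an ADME assay for permeability, using PAMPA, with a stated time of 30 min, at pH 7.4 (a higher number here means that the compound crosses the layer faster, a lower number that the compound crosses the layer more slowly), compound 1 gives 1680 10^-6 cm/s. Compound 2 `N=c1c2c(-c3ccccc3)c(-c3ccccc3)n(CC3CCCCC3)c2ncn1CCCO` stands on a limit rather than a number. In this assay compound 2 gives > 1000 10^-6 cm/s, which is a limit of the assay, not a measured value. For compound 3 `N=c1c2c(-c3ccccc3)c(-c3ccccc3)n(CC3CCCCC3)c2ncn1C1CCOCC1` the entry in this assay reads "nd" (no result reported), so no result exists there. Compound 4 `COc1ccc(Cn2c(-c3ccccc3)c(-c3ccccc3)c3c(=N)n(CCCO)cnc32)cc1` has not been measured; it differs from compound 2 in one place: 4-methoxyphenyl in place of cyclohexyl on a saturated chain carbon bound to an aromatic nitrogen. Within the data shown here, no pair of measured compounds differing in one place is available, so the step has no measured precedent. Given that compound 2 sits at the limit of > 1000 10^-6 cm/s in this assay, at which 1 of the 3 values shown sits, the expected step is a number no higher from compound 2 to compound 4 (the limit leaves the size open), none beyond the usual scatter. Compound 4 is expected to give 1000 10^-6 cm/s, between 400 10^-6 cm/s and 2500 10^-6 cm/s.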

Compound 4, apparent permeability: > 1000 10^-6 cm/s
Compound 4: no number, only a limit (the forecaster's own chance of this, stated with the estimate: 40%); the middle value lies on the limit itself.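

No step can be read from compound 2 to compound 4, because each stands on a limit of this assay, not a number: the limit of > 1000 10^-6 cm/s in this assay, at which 2 of the 4 values shown sit.

The compounds shown leave open whether 4-methoxyphenyl in place of cyclohexyl changes apparent permeability at all.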